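A few compounds are considered here, and "the series" means these few. Any claim that something is new, unique, unknown or untested is made for them only; others in the source may bear on it.

Measured so far in a functional assay on MCF7 cells (Homo sapiens) for inhibition, read by sulforhodamine B assay; on this read-out lower numbers stand for stronger inhibition and higher numbers for weaker inhibition:

- compound 1 `O=C1C(Nc2ccccc2F)=CC(=O)c2c1nc1n2[C@H]2OC[C@@H](O)[C@H]2OC1`: > 4000 nM
- compound 2 `CCOc1ccc(NC2=CC(=O)c3nc4n(c3C2=O)[C@H]2OC[C@@H](O)[C@H]2OC4)cc1`: 1430 nM
- compound 3 `O=C1C(NC2CCCCC2)=CC(=O)c2c1nc1n2[C@H]2OC[C@@H](O)[C@H]2OC1`: > 16000 nM

Among the compounds with values here, compound 2 holds the only actual number among the three values shown. The value of compound 1 is a limit of this assay, not a number. The value of compound 3 is likewise a limit. Between them lies the one step measured, a step that the two limits leave unreadable from compound 1 to compound 3, whose size cannot be read, since both ends sit at limits, the limit of > 4000 nM in this assay, at which 1 of the 3 values shown sits, and (the limit of > 16000 nM in this assay, at which 1 of the 3 values shown sits).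

Compound 4 `O=C1C=C(Nc2cccc(Cl)c2)C(=O)c2c1nc1n2[C@H]2OC[C@@H](O)[C@H]2OC1` is not yet measured. It differs from compound 2 in one place: 3-chlorophenyl in place of 4-ethoxyphenyl on an amine nitrogen. Within the data shown here, no measured step swaps one aromatic ring on this amine nitrogen for another, so none bears directly on this change; the unreadable step from compound 1 to compound 3 gives no size to lean on. The expectation for compound 4 therefore stays close to compound 2, with a wide range allowing either direction and some chance of a limit.

Compound 4 is expected to give about 2500 nM in this assay, between 700 nM and 10000 nM.

This estimate means a step of a 1.7-fold higher number from compound 2 to compound 4 (0.24 log units; within the scatter), expected to be modest.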

Compound 4, half-maximal inhibitory concentration: 4720 nM
Estimate against measurement, compound 4: 1.9-fold (0.28 log units) below, and the stated range covers the measured number.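

In this assay, within the data shown here, the swap of 3-chlorophenyl for 4-ethoxyphenyl gives a 3.3-fold higher number from compound 2 to compound 4 (0.52 log units; beyond the scatter) and this is the first step in the set whose size can be read. It shows that the outcome at this amine nitrogen depends on what the aromatic ring carries, even though a six-membered aromatic ring of carbon only sits there in both compounds, and the 4-ethoxyphenyl compound has the lower number of the pair. Nothing measured here accounts for this step.

The swap removes the ethoxy group, adds a chlorine and changes the numbered ring position all at once, so the compounds shown cannot tell which of these matters. A plain phenyl group on the same nitrogen would help to separate these contributions, as would a 3-ethoxyphenyl group.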